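From benzyl to 4-fluorobenzyl: what tolerance to expect

A few compounds are considered here, and "the series" means these few. Any claim that something is new, unique, unknown or untested is made for them only; others in the source may bear on it.

Measured so far in an ADME assay on HepG2 2.2.15 cells (Homo sapiens) for cytotoxicity, read by MTT assay, with stated times of 48 h and 9 days; a higher number here means that more compound is tolerated, a lower number that less compound is tolerated:
- compound 1 `COc1ccc2c(=O)c(/C=C/C(=O)Nc3cccc(C)c3)coc2c1` gives 554000 nM
- compound 2 `O=C(/C=C/c1coc2cc(O)ccc2c1=O)NCc1ccccc1` gives 436000 nM
- compound 3 `COc1ccc2c(=O)c(/C=C/C(=O)NCc3ccccc3)coc2c1` gives 376000 nM

In this assay compound 2 gives 436000 nM and lies within the usual scatter of both other compounds, so these three numbers cannot be firmly ranked. The next compound, compound 4 `O=C(/C=C/c1coc2cc(O)ccc2c1=O)NCc1ccc(F)cc1` differs from compound 2 in one place (fluoro in place of hydrogen on an aromatic carbon), which turns benzyl into 4-fluorobenzyl. Within the data shown here, no measured pair shows this exact change, so the evidence is indirect. Swapping the whole group on the amide nitrogen gave a 1.5-fold lower number from compound 1 to compound 3 (0.17 log units; within the scatter) while putting methyl in place of hydrogen on an oxygen of the core gave a 1.2-fold lower number from compound 2 to compound 3 (0.06 log units; within the scatter) so no step beyond the scatter is expected from a single fluoro in place of hydrogen, in either direction. The estimated step is a 1.1-fold lower number from compound 2 to compound 4 (0.04 log units; within the scatter) as a best guess. For compound 4 the expected value is 400000 nM with an estimated range from 220000 nM to 700000 nM in repeated measurements.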

Compound 4, half-maximal cytotoxic concentration: 357000 nM
For compound 4 the middle estimate is 1.1-fold (0.05 log units) above the measured one; low and high end bracket the measured number.
By their numbers in this assay, from the lowest: compounds 4, 3, 2 and 1 (each within the scatter of the next).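

In this assay, among these compounds, fluoro in place of hydrogen can now be read directly for the first time, and the result is a 1.2-fold lower number from compound 2 to compound 4 (0.09 log units; within the scatter) within a single change on the benzyl group. The earlier steps shown here involved a whole amide group or the oxygen on the core, whereas this pair differs by one atom on an aromatic carbon, para to a large group. At this place, therefore, 4-fluorobenzyl cannot be told apart from benzyl in tolerance, and no measurement at hand offers a reason for this result.

Fluoro is the only group shown at this place, so it remains open whether methoxy, an amine or a carboxylic acid would also stay within the scatter. From the compounds shown here alone, it is also open whether fluoro would give a similar result on the core of compound 3.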